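Trifluoromethyl for methyl, made twice in one series

The compounds below may be only part of what the source reports. "The series", "measured", "known", "first", "only" and "open" are said of these compounds alone.

Measured so far, in a functional assay on HL-60 cells (Homo sapiens) for cytotoxicity, read by WST assay, with a stated time of 48 h; a lower number here means that less compound is needed, a higher number that more compound is needed for the effect:
compound 1, `Cc1ccccc1C[C@H]1C(=O)OC[C@@H]1Cc1ccccc1`: 57000 nM
compound 2, `O=C1OC[C@H](Cc2ccccc2)[C@H]1Cc1ccccc1C(F)(F)F`: 37000 nM
compound 3, `Cc1cccc(C[C@H]2C(=O)OC[C@@H]2Cc2ccccc2)c1`: 53000 nM

All three numbers lie within the usual scatter of one another. The step of a 1.5-fold lower number from compound 1 to compound 2 (0.19 log units; within the scatter) is trifluoromethyl in place of methyl on an aromatic carbon; the step of a 1.1-fold lower number from compound 1 to compound 3 (0.03 log units; within the scatter) is 3-methylphenyl in place of 2-methylphenyl on a saturated chain carbon bound to a saturated ring carbon, so the two cores differ only in where the methyl sits.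

Compound 4, `O=C1OC[C@H](Cc2ccccc2)[C@H]1Cc1cccc(C(F)(F)F)c1`, is not yet measured in this assay. It differs from compound 3 by trifluoromethyl in place of methyl on an aromatic carbon. This is the same kind of change as from compound 1 to compound 2, not the same: in compound 2 the trifluoromethyl stands ortho to a large group, in compound 4 meta to a large group.

The earlier step of this kind, a 1.5-fold lower number from compound 1 to compound 2 (0.19 log units; within the scatter), stayed within the scatter. On that, and on the close values of compound 1 and compound 3, the step from compound 3 to compound 4 is expected to be a 1.4-fold lower number from compound 3 to compound 4 (0.14 log units; within the scatter), again within the scatter. For compound 4 the estimate in this assay is 38000 nM, expected between 20000 nM and 75000 nM.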

Compound 4, half-maximal effective concentration: 34000 nM
Beside the measured number, compound 4's estimate is 1.1-fold (0.05 log units) above it; low and high end bracket the measured number.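

In this assay, trifluoromethyl in place of methyl on an aromatic carbon gives a 1.6-fold lower number from compound 3 to compound 4 (0.19 log units; within the scatter). Set beside the earlier step on the other core, the change carries over with no difference that can be told from the scatter: the same change on two cores in this assay, a 1.5-fold lower number (0.19 log units; within the scatter) from compound 1 to compound 2 and a 1.6-fold lower number (0.19 log units; within the scatter) from compound 3 to compound 4, 1.0-fold (0.01 log units) apart, within the scatter of two such steps

What this shows is limited: on these two cores the change leaves the number within the scatter, and the agreement is between two small steps, so it is no evidence of a real gain in either case or of a transferable effect on any further core.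

The compounds shown leave open whether any group on this aromatic carbon moves the number beyond the scatter, for example an amine, a carboxylic acid or a longer chain in place of the methyl. They also leave open whether such a group on the other aromatic ring would behave the same way in this assay.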